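Swapping the aryl for neopentyl on the shared core

This account rests on a few compounds, and the source may have more. Where it says the series, first, only, none or still open, it means among the compounds named here.

Three analogues sharing the core of compound 1 `COc1ccc(Cc2cnc(CCc3ccc(-c4ccccc4C(=O)O)cc3)[nH]2)cc1` have been measured in an in vitro functional assay on cells for agonist activity at Bombesin receptor subtype-3 (Mus musculus), read by luminescence and calcium flux; a higher number here means that more compound is needed for the effect, a lower number that less compound is needed. Compound 1 gives 513 nM. Compound 2 `O=C(O)c1ccccc1-c1ccc(CCc2ncc(Cc3ccccc3F)[nH]2)cc1` gives 9.5 nM, and compound 3 `O=C(O)c1ccccc1-c1ccc(CCc2ncc(Cc3ccc(F)cc3)[nH]2)cc1` gives 50 nM. Compound 3 therefore stands second highest of the three numbers: the step of a 5.3-fold higher number from compound 2 to compound 3 (0.72 log units; beyond the scatter) is modest, while a 10-fold lower number from compound 1 to compound 3 (1.01 log units; beyond the scatter) is large, as is a 54-fold lower number from compound 1 to compound 2 (1.73 log units; beyond the scatter).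

Compound 4 `CC(C)(C)CCc1cnc(CCc2ccc(-c3ccccc3C(=O)O)cc2)[nH]1` differs from compound 3 by neopentyl in place of 4-fluorophenyl on a saturated chain carbon bound to an aromatic carbon. All three measured steps bear on this position, and each shows it to matter beyond the scatter, yet every one of them exchanges one ring-bearing group for another; none removes the ring altogether. They show the position is sensitive, but give no direction for a chain in place of a ring. He therefore expects a step of a 3.0-fold higher number from compound 3 to compound 4 (0.48 log units; beyond the scatter) in this assay, with wide uncertainty, leaning toward a higher number. For compound 4 he estimates 150 nM, within a range from 25 nM to 900 nM.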

Compound 4, half-maximal effective concentration: 6.2 nM
Beside the measured number, compound 4's estimate is 24-fold (1.38 log units) above it, outside the stated range (below it).
By their numbers in this assay, from the lowest: compounds 4 and 2 (each within the scatter of the next); then compound 3; then compound 1.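

In this assay a chain with no ring serves at this position as well as the best ring-bearing group shown: neopentyl gives an 8.1-fold lower number from compound 3 to compound 4 (0.91 log units; beyond the scatter) and an 83-fold lower number from compound 1 to compound 4 (1.92 log units; beyond the scatter) while a 1.5-fold lower number from compound 2 to compound 4 (0.19 log units; within the scatter) leaves the two indistinguishable. The earlier steps shown here only traded one ring-bearing group for another, whereas this one shows that the aromatic ring can be given up here with no loss against 2-fluorophenyl, and with a clear gain over 4-fluorophenyl and 4-methoxyphenyl. Nothing measured here accounts for this result.

Going by these compounds, whether the branching of neopentyl matters remains open, as does how an unbranched pentyl chain or a cyclohexyl ring would compare at this position. Equally open, on these data alone, is how far the position accepts a chain ending in an amine or a hydroxyl group.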